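Removing the Carbamate and Installing an Amine on the Shared Core

The source may hold more compounds than are shown below. What is called first, only, known or untested is meant among the compounds shown, and "the series" means these compounds.

Of the compounds shown here, three built on one shared core have been tested in an assay on cell membranes for displacement of a labelled ligand from proteinase-activated receptor 1 (Homo sapiens), read by scintillation counting, with a stated time of 60 min; on this read-out lower numbers stand for stronger inhibition and higher numbers for weaker inhibition. Compound 1 `OC1C[C@@H]2CCCC[C@@H]2[C@H]1/C=C/c1ccc(-c2cccc(F)c2)cn1` carries a free hydroxyl on the saturated ring carbon, and in this assay compound 1 gives 220 nM. Compound 2 `CS(=O)(=O)OC1C[C@@H]2CCCC[C@@H]2[C@H]1/C=C/c1ccc(-c2cccc(F)c2)cn1` caps that oxygen with a methylsulfonyl, and compound 2 gives 6.4 nM. Compound 3 `O=C(Nc1ccccc1)OC1C[C@@H]2CCCC[C@@H]2[C@H]1/C=C/c1ccc(-c2cccc(F)c2)cn1` caps the same oxygen with a phenylcarbamoyl, and compound 3 gives 360 nM. Compound 3 therefore shows the highest of the three numbers, although one of its two gaps (a 1.6-fold higher number from compound 1 to compound 3 (0.21 log units; within the scatter)) lies within the scatter, while the other (a 56-fold higher number from compound 2 to compound 3 (1.75 log units; beyond the scatter)) is large and beyond it.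

Compound 4 `NC1C[C@@H]2CCCC[C@@H]2[C@H]1/C=C/c1ccc(-c2cccc(F)c2)cn1` alters this position once more: amino in place of (phenylcarbamoyl)oxy on a saturated ring carbon. For the measured compounds named here, none of the measured steps installs an amino, so none bears on it directly; the comparison of compound 1 with compound 3 is the closest guide, since it shows what the core does with only a single small group at this carbon. Because the hydroxyl of compound 1 gives 220 nM and the amino is likewise a one-atom group, compound 4 is expected to fall in that region. Compound 4 is estimated at 200 nM, with a range from 60 nM to 700 nM, which corresponds to an expected step of a 1.8-fold lower number from compound 3 to compound 4 (0.26 log units; within the scatter).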

Compound 4, half-maximal inhibitory concentration: 230 nM
Estimate against measurement, compound 4: 1.2-fold (0.06 log units) below; the range from low to high includes it.
By their numbers in this assay, from the lowest: compound 2; then compounds 1, 4 and 3 (each within the scatter of the next).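

In this assay, for the compounds shown here, amino in place of hydroxy on this saturated ring carbon gives a 1.0-fold higher number from compound 1 to compound 4 (0.02 log units; within the scatter), so changing the single group on this carbon from oxygen to nitrogen leaves the reading where it was. Amino in place of the much larger (phenylcarbamoyl)oxy, which takes away 10 heavy atoms and an aromatic ring, gives a 1.6-fold lower number from compound 3 to compound 4 (0.19 log units; within the scatter), so among these compounds the count of atoms at this position does not by itself set the number. The (methylsulfonyl)oxy group alone stands apart, with amino in its place giving a 36-fold higher number from compound 2 to compound 4 (1.56 log units; beyond the scatter), and the amino, hydroxy and (phenylcarbamoyl)oxy compounds all lie on the far side of that large gap.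

No measurement shown here explains why these groups give the numbers they do. The compounds shown leave open whether a methylsulfonyl carried on the nitrogen of the amino group, or a longer ethylsulfonyl on the oxygen, would keep the reading near that of compound 2 at 6.4 nM.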